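This account rests on a few compounds, and the source may have more. Where it says the series, first, only, none or still open, it means among the compounds named here.

In a functional assay on SW480 cells (Homo sapiens) for antiproliferative activity, read by sulforhodamine B assay, with a stated time of 48 h (on this read-out higher numbers stand for weaker inhibition and lower numbers for stronger inhibition), compound 1 (`COc1ccc(/C=C/C(=O)c2ccccc2-c2ccc(F)cc2)cc1`) gives 61 nM and stands within the scatter of both measured compounds that differ from it in one place. Compound 2 (`COc1ccc(/C=C/C(=O)c2ccccc2-c2ccc(F)cc2)cc1O`) gives 57 nM in this assay and compound 3 (`CN(C)c1ccc(/C=C/C(=O)c2ccccc2-c2ccc(F)cc2)cc1`) gives 41 nM in the same read-out. Two steps are available: hydroxy in place of hydrogen on an aromatic carbon gives a 1.1-fold lower number from compound 1 to compound 2 (0.03 log units; within the scatter) and dimethylamino in place of methoxy on an aromatic carbon gives a 1.5-fold lower number from compound 1 to compound 3 (0.17 log units; within the scatter) in this series. Neither step leaves the scatter.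

Compound 4 (`O=C(/C=C/c1cccs1)c1ccccc1-c1ccc(F)cc1`) is still unmeasured. Its change from the core of compound 1 is thiophen-2-yl in place of 4-methoxyphenyl on a double-bonded chain carbon bound to a double-bonded chain carbon in the form of thiophen-2-yl in place of 4-methoxyphenyl on a double-bonded chain carbon bound to a double-bonded chain carbon.

Within the data shown here, both measured steps alter only the group that leaves here, and no measured compound replaces that whole group, so they bear on this change only loosely. The small size of those steps argues against a large expected move, but the evidence is thin. The step expected in this assay is a 1.5-fold higher number from compound 1 to compound 4 (0.17 log units; within the scatter) as an estimate, with a slight lean toward weaker inhibition and wide bounds. Compound 4 is estimated at 90 nM with an expected range from 30 nM to 280 nM in repeated measurements.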

Compound 4, half-maximal inhibitory concentration: 16000 nM
Beside the measured number, compound 4's estimate is 180-fold (2.25 log units) below it; measured number outside the range, above it.
By their numbers in this assay, from the lowest: compounds 3, 2 and 1 (each within the scatter of the next); then compound 4.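

Working notes on the series: in this assay, thiophen-2-yl in place of 4-methoxyphenyl on a double-bonded chain carbon bound to a double-bonded chain carbon gives a 260-fold higher number from compound 1 to compound 4 (2.42 log units; beyond the scatter), the only step shown that lies beyond the scatter, and a large one. The two earlier steps edited substituents and kept the six-membered aromatic ring of carbon only, and both stayed within the scatter; this step replaces the whole group with one five-membered aromatic ring with 1 hetero atom, so the small earlier steps do not show how far the read-out can move at this position. Nothing shown accounts for the size of this step.

This single replacement changes the ring size, brings in sulfur and removes the methoxy group all at once, and the compounds shown do not separate these changes. Open, from the compounds shown here alone, are the values of an unsubstituted phenyl group and of a thiophen-2-yl group carrying a methoxy group at this position, which would show whether the loss follows the ring or the methoxy group.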